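Furan for thiophene on the shared core: expected effect

The source may hold more compounds than are shown below. What is called first, only, known or untested is meant among the compounds shown, and "the series" means these compounds.

Measured so far:
compound 1, `COc1ncnc2c1c(-c1ccsc1)cn2[C@@H]1O[C@H](CO)[C@@H](O)[C@H]1O`: 7640 nM
compound 2, `CN(C)c1ncnc2c1c(-c1ccsc1)cn2[C@@H]1O[C@H](CO)[C@@H](O)[C@H]1O`: > 20000 nM

Among the compounds with values here, in a functional assay on CEM-DNR-bulk cells (Homo sapiens), read by MTT assay, with a stated time of 72 h (a lower number here means a stronger inhibitor, a higher number a weaker inhibitor), compound 1 gives 7640 nM, the only number in the set so far. Compound 2 reaches only the assay limit, > 20000 nM, so no number is known for it. Within the data shown here, the one measured step, an at least 2.6-fold higher number from compound 1 to compound 2 (0.41 log units; beyond the scatter), concerns the group on the other aromatic carbon of the core and sits at the limit of > 20000 nM in this assay, at which 1 of the 2 values shown sits.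

Compound 3, `COc1ncnc2c1c(-c1ccoc1)cn2[C@@H]1O[C@H](CO)[C@@H](O)[C@H]1O`, is not yet measured. It differs from compound 1 by furan-3-yl in place of thiophen-3-yl on an aromatic carbon. Among the measured compounds shown here, no measured step touches this position, so the step from compound 1 to compound 2 gives no direct guidance; the expectation rests on the change alone. The step is expected to stay within the scatter, a 1.2-fold higher number from compound 1 to compound 3 (0.07 log units; within the scatter). For compound 3 the estimate in this assay is 9000 nM, with a range from 3500 nM to 24000 nM.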

Compound 3, half-maximal inhibitory concentration: > 20000 nM
Compound 3 was reported as a limit; the forecaster's own chance of this, stated with the estimate: 25%; at least 2.2-fold (0.34 log units) between middle value and limit.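

Thiophen-3-yl is not interchangeable with furan-3-yl at this position: in this assay, the swap gives an at least 2.6-fold higher number from compound 1 to compound 3 (0.41 log units; beyond the scatter), although the two groups match in heavy-atom and hydrogen-bond acceptor counts. On these data alone, compound 3 is reported only as a limit, > 20000 nM, so the full size of this step remains unknown. The change to the five-membered aromatic ring now joins the methoxy change in reaching the top of the measurable range: the limit of > 20000 nM in this assay, at which 2 of the 3 values shown sit.

The data leave open how far compound 3 lies beyond its limit, so they do not rank it against compound 2. They also leave open whether a larger aromatic group at this position, such as phenyl or pyridin-3-yl, would give a lower number than compound 1.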